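Isopropoxycarbonyl for pyrrolidinylcarbonyl: an expected permeability step

The source may report more compounds than this note shows. Statements on the series, on what has been measured and on what is new or still open speak of the compounds shown alone.

Compound 2 `Cn1cncc1CN1CC(N(CC2CCN(C(=O)N3CCCC3)CC2)S(=O)(=O)c2ccccn2)Cc2cc(C#N)ccc21` has been measured in an ADME assay on Caco-2 cells (Homo sapiens) for permeability, in the apical to basolateral direction (on this read-out higher numbers stand for higher permeability and lower numbers for lower permeability), where compound 2 gives 0.6 10^-6 cm/s. Among the measured compounds shown here, only one other number exists: compound 1 `Cn1cncc1CN1CC(N(CC2CCN(C(=O)CC(F)(F)F)CC2)S(=O)(=O)c2ccccn2)Cc2cc(C#N)ccc21` gives 0.5 10^-6 cm/s in this assay. The step of a 1.2-fold higher number from compound 1 to compound 2 (0.08 log units; within the scatter) lies within the scatter, so compound 2 and compound 1 stand side by side, and neither can be placed above the other. Compound 3 `CC(C)OC(=O)N1CCC(CN(C2Cc3cc(C#N)ccc3N(Cc3cncn3C)C2)S(=O)(=O)c2ccccn2)CC1` differs from compound 2 by isopropoxy in place of pyrrolidin-1-yl on a carbonyl carbon. For the measured compounds named here, the single measured step is the only one that bears on this change, since it too exchanged the group on that carbonyl carbon, and it stayed within the scatter. Nothing in the data points to a larger movement here. Compound 3 is therefore expected to give about 0.8 10^-6 cm/s in this assay, with a range from 0.3 10^-6 cm/s to 2 10^-6 cm/s. The expected step amounts to a 1.3-fold higher number from compound 2 to compound 3 (0.12 log units; within the scatter), which is within the scatter.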

Compound 3, apparent permeability: 1 10^-6 cm/s
Compound 3: the middle estimate sits 1.3-fold (0.10 log units) below what was measured, and the stated range covers the measured number.
By their numbers in this assay, from the lowest: compounds 1, 2 and 3 (each within the scatter of the next).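

In this assay, a third kind of group on this carbonyl carbon, isopropoxy, joins 2,2,2-trifluoroethyl and pyrrolidin-1-yl, and the read-out again shows no separation. Both new steps are printed as within the scatter (a 1.7-fold higher number from compound 2 to compound 3 (0.22 log units; within the scatter); a 2.0-fold higher number from compound 1 to compound 3 (0.30 log units; within the scatter)). Among the compounds shown here, the earlier pair offered only one exchange at this position, whereas the three compounds now show that carbonyl substituents joined through carbon, nitrogen and oxygen cannot be told apart here, even with a ring exchanged for an open branched group. Nothing at hand explains these numbers.

Going by these compounds, what remains open is whether any other group on this carbonyl carbon would step beyond the scatter. A primary amine or a carboxylic acid on a longer chain would test this, and neither is among the compounds shown.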